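Swapping dichlorophenyl for aminophenyl: a step into the unknown

This account rests on a few compounds, and the source may have more. Where it says the series, first, only, none or still open, it means among the compounds named here.

In a functional assay (muscle tissue) with Cavia porcellus as the target (on this read-out lower numbers stand for an effect already at smaller amounts and higher numbers for an effect only at larger amounts of compound), compound 2 (`COC(=O)C1=C(C)N=C(C)/C(=C(\O)OC)C1c1cc(Cl)cc(Cl)c1`) gives 93.3 nM and sits between the other two: compound 3 (`COC(=O)C1=C(C)N=C(C)/C(=C(\O)OC)C1c1c(F)c(F)c(F)c(F)c1F`) gives 4.37 nM and compound 1 (`COC(=O)C1=C(C)N=C(C)/C(=C(\O)OC)C1c1ccc(Cl)cc1`) gives 8130 nM at the high end. Compound 4 (`COC(=O)C1=C(C)N=C(C)/C(=C(\O)OC)C1c1ccccc1N`) changes the group on a saturated ring carbon of the shared core (2-aminophenyl in place of 3,5-dichlorophenyl on a saturated ring carbon). Within the data shown here, only one measured step bears on this (an 87-fold lower number from compound 1 to compound 2 (1.94 log units; beyond the scatter)) and it is large, showing that a change of that group alone can move the number far. Among the measured compounds shown here, no measured compound carries an amino group. Like compound 1 at 8130 nM in this test, compound 4 has a single substituent on its phenyl, so a large step to a higher number is expected in this assay with wide uncertainty. The estimated step is large (an 11-fold higher number from compound 2 to compound 4 (1.03 log units; beyond the scatter)). For compound 4 the estimated value is 1000 nM (100 nM to 10000 nM).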

Compound 4, half-maximal effective concentration: 39800 nM
Estimate against measurement, compound 4: 40-fold (1.60 log units) below; the measured number lies above the stated range.
By their numbers in this assay, from the lowest: compound 3; then compound 2; then compound 1; then compound 4.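

In this assay, replacing either chlorinated phenyl with 2-aminophenyl raises the number, with a 430-fold higher number from compound 2 to compound 4 (2.63 log units; beyond the scatter) and a modest 4.9-fold higher number from compound 1 to compound 4 (0.69 log units; beyond the scatter). Compound 4 therefore has the highest number of the four, showing that this saturated ring carbon tolerates some phenyl groups far less well than the chlorinated and fluorinated ones seen before. Nothing measured here gives a reason for this. On these data alone, whether the high number belongs to the amino group itself remains open. A hydroxyl or methoxy group on that phenyl would offer a direct comparison.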